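The source may hold more compounds than are shown below. What is called first, only, known or untested is meant among the compounds shown, and "the series" means these compounds.

In a functional assay on KB cells (Homo sapiens) for antiproliferative activity, read by sulforhodamine B assay, with a stated time of 3 days (a higher number here means a weaker inhibitor of growth, a lower number a stronger inhibitor of growth), compound 1 `O=C(Nc1nccs1)c1cccc(Nc2ncc(F)c(Nc3ccc(F)cc3)n2)c1` gives > 10000 nM, which is a limit of the assay and not a number. Among the measured compounds shown here, compound 2 `CN1CCC(C(=O)Nc2cccc(Nc3ncc(F)c(Nc4ccc(F)cc4)n3)c2)CC1` gives 1700 nM, the only actual number so far. Compound 3 `O=C(Nc1cc(Cl)cc(Cl)c1)c1cccc(Nc2ncc(F)c(Nc3ccc(F)cc3)n2)c1` has (3,5-dichlorophenyl)carbamoyl in place of ((1-methylpiperidin-4-yl)carbonyl)amino on an aromatic carbon. For the measured compounds named here, this brings back a carbamoyl group like that of compound 1, so the one measured step, an at least 5.8-fold lower number from compound 1 to compound 2 (0.76 log units; beyond the scatter), is expected to run largely in reverse, towards a higher number in this assay. The expected step is a 4.1-fold higher number from compound 2 to compound 3 (0.61 log units; beyond the scatter). For compound 3 the estimated value is 7000 nM, within a range of 2500 nM to 20000 nM.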

Compound 3, concentration for 50% growth inhibition: 20100 nM
Compound 3: the middle estimate sits 2.9-fold (0.46 log units) below what was measured; measured number above the stated range.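

Replacing ((1-methylpiperidin-4-yl)carbonyl)amino with (3,5-dichlorophenyl)carbamoyl on this aromatic carbon gives, in this assay, a 12-fold higher number from compound 2 to compound 3 (1.07 log units; beyond the scatter). Compound 3 thus gives a second carbamoyl example at this place that is far weaker than compound 2, and this time as a true number. Its step from compound 1 cannot be read, because the value of compound 1 is a limit: the limit of > 10000 nM in this assay, at which 1 of the 3 values shown sits.

Compound 2 differs from the others in both its ring and the direction of its amide, so the two changes remain tangled. A carbamoyl group bearing 1-methylpiperidin-4-yl would separate them.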